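A few compounds are considered here, and "the series" means these few. Any claim that something is new, unique, unknown or untested is made for them only; others in the source may bear on it.

Measured so far in a functional assay on MT4 cells (Homo sapiens) for cytotoxicity; on this read-out lower numbers stand for stronger inhibition and higher numbers for weaker inhibition:
- compound 1 `N#Cc1c(N)cccc1S(=O)(=O)c1ccccc1`: > 5000 nM, a limit
- compound 2 `Cc1ccc(S(=O)(=O)c2cccc(N)c2C#N)cc1`: > 200000 nM, a limit

Compound 2 is known only through its limit of > 200000 nM, so it gives no exact number to start from. Compound 3 `N#Cc1c(N)cccc1S(=O)(=O)c1ccc(Cl)cc1` has chloro in place of methyl on an aromatic carbon.

Going by the values given here, the only measured step bearing on this is a step that the two limits leave unreadable from compound 1 to compound 2. It concerns the same place on the ring, but it has no readable size and gives no size for the new change. Among the compounds with values here, no large step in this assay is therefore expected. For compound 2, a step toward lower numbers is the likelier direction because > 200000 nM is a limit, though this expectation is weak.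

Compound 3 is estimated at 100000 nM, with an expected range of 10000 nM to 300000 nM. This estimate means an expected at least 2.0-fold lower number from compound 2 to compound 3 (0.30 log units; that floor lies within the scatter).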

Compound 3, half-maximal inhibitory concentration: > 5000 nM
Compound 3: only a limit was reported (the forecaster's own chance of this, stated with the estimate: 65%); the middle value lies beyond the limit too.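

In this assay compound 3 is known only through a limit, > 5000 nM. No step can be read among compound 1, compound 2 and compound 3, since all three values are limits. The compounds shown leave open how hydrogen, methyl and chloro on this aromatic carbon compare.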